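Sulfonamide in place of carboxylate at the pendant phenyl

The source may report more compounds than this note shows. Statements on the series, on what has been measured and on what is new or still open speak of the compounds shown alone.

Measured compounds: compound 1 `CCCS(=O)(=O)Nc1ccc(F)c(C(=O)c2n[nH]c3ncc(-c4ccc(O)cc4)cc23)c1F` gives 0.75% in an assay for binding affinity to dual specificity mitogen-activated protein kinase kinase 4 (Homo sapiens), read by KINOMEscan, tested at 100 nM; a higher number here means a weaker effect of the compound at the concentration tested, a lower number a stronger effect; compound 2 `CCCS(=O)(=O)Nc1ccc(F)c(C(=O)c2n[nH]c3ncc(-c4ccc(Cl)c(Cl)c4)cc23)c1F` gives 45%; compound 3 `CCCS(=O)(=O)Nc1ccc(F)c(C(=O)c2n[nH]c3ncc(-c4ccc(C(=O)O)cc4)cc23)c1F` gives 0.1%.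

Compound 3 stands lowest of the three numbers, with compound 1 within the scatter of it and compound 2 far above. Compound 4 `CCCS(=O)(=O)Nc1ccc(F)c(C(=O)c2n[nH]c3ncc(-c4ccc(S(N)(=O)=O)cc4C)cc23)c1F` differs from compound 3 as follows: 2-methyl-4-sulfamoylphenyl in place of 4-carboxyphenyl on an aromatic carbon. For the measured compounds named here, the steps that bear on this change are a number 44.9 percentage points lower from compound 2 to compound 3 (beyond the scatter) and a number 0.7 percentage points lower from compound 1 to compound 3 (within the scatter). Going by the values given here, a group with one hydrogen-bond donor is kept, which points to a small step in this assay, though the added methyl has no precedent here. The expected step is a number 2.9 percentage points higher from compound 3 to compound 4 (within the scatter). Compound 4 is estimated at 3%, range 0.1% to 30%.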

Compound 4, a percentage reported as activity, at one concentration (the size of the read-out at that concentration, not a potency): 3.1%
Compound 4: middle estimate off by 0.1 percentage points, on the low side; the measured number falls inside the stated range.
By their numbers in this assay, from the lowest: compounds 3, 1 and 4 (each within the scatter of the next); then compound 2.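

In this assay the 2-methyl-4-sulfamoylphenyl group reads with the 4-carboxyphenyl group (a number 3 percentage points higher from compound 3 to compound 4 (within the scatter)) and the 4-hydroxyphenyl group (a number 2.4 percentage points higher from compound 1 to compound 4 (within the scatter)). Against the 3,4-dichlorophenyl group the step is large (a number 41.9 percentage points lower from compound 2 to compound 4 (beyond the scatter)), so at this position a sulfamoyl group with an added ring methyl stays with the carboxy and hydroxy compounds, and that is the new finding. No measurement here gives a reason for this.

From the compounds shown here alone, what the methyl contributes alone remains open, as does the reading of a plain 4-sulfamoylphenyl group. Going by these compounds, a 4-aminophenyl group at this position is also open.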